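The source may report more compounds than this note shows. Statements on the series, on what has been measured and on what is new or still open speak of the compounds shown alone.

Compound 3 `O=C(c1ccc(Cl)cc1)n1c(-c2cn(-c3ccccc3)nc2-c2ccc(C(F)(F)F)cc2)nc2ccccc21` was measured in an ADME assay on HEK-293T cells (Homo sapiens) for cytotoxicity, read by MTT assay, with a stated time of 24 h (a lower number here means that less compound is tolerated, a higher number that more compound is tolerated), and gives 181000 nM. Among the three compounds measured so far it holds the second highest number; compound 1 `O=C(c1ccccc1)n1c(-c2cn(-c3ccccc3)nc2-c2ccc(C(F)(F)F)cc2)nc2ccccc21` gives 168000 nM and compound 2 `Cc1ccc(-c2nn(-c3ccccc3)cc2-c2nc3ccccc3n2C(=O)c2cccc(C)c2)cc1` gives 195000 nM, and both of these lie within the scatter of compound 3. Among the compounds with values here, the one single-point step that is measured, a 1.1-fold higher number from compound 1 to compound 3 (0.03 log units; within the scatter), shows that this assay hardly moved when the aroyl group was varied at one position.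

Compound 4 `Cc1cccc(C(=O)n2c(-c3cn(-c4ccccc4)nc3-c3ccc(C(F)(F)F)cc3)nc3ccccc32)c1` differs from compound 3 by 3-methylphenyl in place of 4-chlorophenyl on a carbonyl carbon. Within the data shown here, no measured step covers exactly this exchange. The step from compound 1 to compound 3 bears on it most closely, since it also alters only the aroyl group on the carbonyl carbon, and it stayed within the scatter. Compound 2 already carries the 3-methylphenyl carbonyl, though with a different group elsewhere, and its value sits within the scatter of compound 3. Taken together, the expectation for compound 4 in this assay is a change no larger than the scatter, a 1.0-fold higher number from compound 3 to compound 4 (0.01 log units; within the scatter). Compound 4 is therefore estimated at 185000 nM, with a likely range from 120000 nM to 280000 nM.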

Compound 4, half-maximal cytotoxic concentration: 154000 nM
For compound 4 the middle estimate is 1.2-fold (0.08 log units) above the measured one; measured number inside the range.
By their numbers in this assay, from the lowest: compounds 4, 1, 3 and 2 (each within the scatter of the next).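

Exchanging 4-chlorophenyl for 3-methylphenyl on a carbonyl carbon whose other neighbour is an aromatic nitrogen leaves this assay within the scatter, with a 1.2-fold lower number from compound 3 to compound 4 (0.07 log units; within the scatter), and the methyl added to the unsubstituted aroyl ring does the same, with a 1.1-fold lower number from compound 1 to compound 4 (0.04 log units; within the scatter). Within the data shown here, compound 4 also supplies the first reading at a place outside the aroyl group: trifluoromethyl in place of methyl on an aromatic carbon gives a 1.3-fold lower number from compound 2 to compound 4 (0.10 log units; within the scatter), so that this exchange also stays within the scatter, and all four compounds now lie within the scatter of their neighbours in the order of their numbers. No measurement at hand offers an explanation for how closely these numbers sit.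

With every step inside the scatter, the compounds shown set no direction for either place and do not show what change would move this number clearly. As far as these compounds go, it remains open whether an amine or a carboxylic acid on the aroyl ring, or a longer chain in place of the 3-methylphenyl on the carbonyl carbon, would take this assay beyond the scatter.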